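Dropping one fluoro from compound 2 toward compound 3

This account rests on a few compounds, and the source may have more. Where it says the series, first, only, none or still open, it means among the compounds named here.

The series shares one core. Compound 1 `Cc1ccc(NS(=O)(=O)c2ccc3c(c2)C(=O)CC(C2CCOCC2)O3)c(C)c1` gives 2.75 in a physicochemical assay for lipophilicity, at pH 7.4; a lower number here means a more polar compound, a higher number a more lipophilic compound. Compound 2 `CC(C)CN(c1ccc(F)cc1F)S(=O)(=O)c1ccc2c(c1)C(=O)CC(C1CCOCC1)O2` gives 3.62 in this assay, the higher of the two numbers, and its gap to compound 1 lies beyond the scatter. Compound 3 `CC(C)CN(c1ccc(F)cc1)S(=O)(=O)c1ccc2c(c1)C(=O)CC(C1CCOCC1)O2` has not been measured. It differs from compound 2 in one place: hydrogen in place of fluoro on an aromatic carbon. The step from compound 2 to compound 3 in this assay is expected to be small and downward, a number 0.22 log units lower from compound 2 to compound 3 (within the scatter), possibly within the scatter. Compound 3 is therefore estimated at 3.4, with a range from 3.1 to 3.7.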

Compound 3, distribution coefficient: 3.48
The estimate for compound 3 lay 0.08 log units below the measured number; low and high end bracket the measured number.
By their numbers in this assay, from the lowest: compound 1; then compounds 3 and 2 (each within the scatter of the next).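

In this assay the change from 2,4-difluorophenyl to 4-fluorophenyl, made on the aromatic carbon ortho to a large group, gives a number 0.14 log units lower from compound 2 to compound 3 (within the scatter) and so leaves hydrogen and fluoro at this position not told apart by this measurement. The earlier compounds shown here offered no such single change. No evidence at hand bears on what lies behind a step of this size. As far as these compounds go, whether an amine or a methoxy group on that carbon would give a step beyond the scatter remains open, as does the effect of removing the remaining fluoro.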